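The source may report more compounds than this note shows. Statements on the series, on what has been measured and on what is new or still open speak of the compounds shown alone.

Measured so far in a functional assay (Nicotiana tabacum); on this read-out higher numbers stand for weaker inhibition and lower numbers for stronger inhibition
Compound 1 `CSc1nc(NC2CCCCC2)c2cccnc2n1` gives 5650 nM
Compound 2 `CCC(CC)Nc1nc(SC)nc2ncccc12` gives 2720 nM
Compound 3 `CSc1nc(NCc2ccccc2)c2cccnc2n1` gives 25200 nM

Compound 3 has the highest number of the three, which makes it the weakest inhibitor so far. Compound 4 `CCOCCNc1nc(SC)nc2ncccc12` differs from it in one place, on a saturated chain carbon bound to a nitrogen on an aromatic ring, where ethoxymethyl stands in place of phenyl (ethoxymethyl in place of phenyl on a saturated chain carbon bound to a nitrogen on an aromatic ring).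

The only measured step among these compounds is a 2.1-fold lower number from compound 1 to compound 2 (0.32 log units; beyond the scatter) and it is modest. It swaps pentan-3-yl for cyclohexyl, so it is only a loose guide. The values say a little more: compound 1 (5650 nM) and compound 2 (2720 nM) have no phenyl, and both lie below compound 3. Among the measured compounds shown here, no measured compound carries ethoxymethyl, so caution is needed. A moderate move towards a lower number is expected, with the estimated step being a 2.5-fold lower number from compound 3 to compound 4 (0.40 log units; beyond the scatter) in this reading. Compound 4 is estimated at 10000 nM with an expected range from 3500 nM to 30000 nM for the measurement.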

Compound 4, half-maximal inhibitory concentration: 7590 nM
Compound 4: the middle estimate sits 1.3-fold (0.12 log units) above what was measured; the measured number falls inside the stated range.
By their numbers in this assay, from the lowest: compound 2; then compounds 1 and 4 (each within the scatter of the next); then compound 3.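

In this assay, the phenyl ring is not required at this position: with ethoxymethyl, which has no ring and brings one hydrogen-bond acceptor, the data show a 3.3-fold lower number from compound 3 to compound 4 (0.52 log units; beyond the scatter). Having no ring does not settle the value on its own, as both side chains lack a ring and yet there is a 2.8-fold higher number from compound 2 to compound 4 (0.45 log units; beyond the scatter), while a ring can be exchanged for the open chain with little consequence, as seen in a 1.3-fold higher number from compound 1 to compound 4 (0.13 log units; within the scatter). No measurement shown here explains these differences.

As far as these compounds go, whether the oxygen of 2-ethoxyethyl matters remains open, and a plain pentyl chain on the same nitrogen would help to test it. The effect of an amine or a hydroxyl group at the end of the chain is also unknown.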